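This account rests on a few compounds, and the source may have more. Where it says the series, first, only, none or still open, it means among the compounds named here.

Four sulfonamides are compared here, each built from two aromatic rings joined through a sulfonamide link, and what is measured is how readily the amide hydrogen is given up. Compound 1 is `O=[N+]([O-])c1cccc(NS(=O)(=O)c2ccc(Cl)cc2)c1` and compound 2 is `O=[N+]([O-])c1cccc(NS(=O)(=O)c2ccc(Br)cc2)c1`. In a physicochemical assay for acid dissociation, compound 1 gives 7.51, and compound 2 gives 7.42. The two differ in one place only: bromo in place of chloro on an aromatic carbon. The step of a number 0.09 log units lower from compound 1 to compound 2 (within the scatter) shows that this exchange left the read-out essentially where it was.

Compound 3 is `O=S(=O)(Nc1ccc(F)cc1)c1ccc(Cl)cc1`. It carries the chloro group of compound 1 on one ring but a different second ring, and how its core differs from that of compound 1 is not broken down here. In this assay, among the compounds with values here, compound 3 gives 8.41, the highest of the three values so far, a number well beyond the scatter above compound 1 and compound 2.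

Compound 4 is `O=S(=O)(Nc1ccc(F)cc1)c1ccc(Br)cc1`, not yet measured. It stands to compound 3 exactly as compound 2 stands to compound 1: bromo in place of chloro on an aromatic carbon. Both exchanges sit para to a large group, so the change is the same. The step from compound 3 to compound 4 is expected to be a number 0.09 log units lower from compound 3 to compound 4 (within the scatter), a size that rests on compound 1 and compound 2, whose step a number 0.09 log units lower from compound 1 to compound 2 (within the scatter) stayed within the scatter. On that basis compound 4 is estimated to give 8.32 in this assay, with a likely range from 8.1 to 8.55.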

Compound 4, acid dissociation constant: 8.38
Compound 4: the middle estimate sits 0.06 log units below what was measured; measured number inside the range.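

In this assay, the exchange of chloro for bromo, on an aromatic carbon para to a large group, gives on the second core a number 0.03 log units lower from compound 3 to compound 4 (within the scatter) and gave on the first core a number 0.09 log units lower from compound 1 to compound 2 (within the scatter) so in these two pairs the change carried over from one core to the other, leaving the read-out essentially where it was. This rests on two pairs only: both steps lie within the scatter, so neither can be read as a real change, and nothing here shows that the exchange would stay this quiet on a third core. No measurement is available that explains why the read-out stays put on either core.

The compounds shown leave open what happens when the group in this same place is neither chloro nor bromo, for instance an amine, a carboxylic acid or a longer chain such as propyl, since two close relatives say little about groups of a very different kind. They also leave open whether the second ring could carry such a group, in place of the nitro or fluoro seen here, without disturbing the quiet behaviour of the chloro-to-bromo exchange.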